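This account rests on a few compounds, and the source may have more. Where it says the series, first, only, none or still open, it means among the compounds named here.

Measured so far in a functional assay on DU-145 cells (Homo sapiens) for inhibition, read by trypan blue exclusion, with a stated time of 96 h; a higher number here means a weaker inhibitor of growth, a lower number a stronger inhibitor of growth:

Compound 1, `Cc1ccc(S/C(=C/c2c(O)cc(O)cc2O)C(=O)c2ccc(Cl)cc2)cc1` — the assay reports only a limit, > 100000 nM.
Compound 2, `Cc1ccc(S(=O)(=O)/C(=C/c2c(O)cc(O)cc2O)C(=O)c2ccc(Cl)cc2)cc1` — the assay reports only a limit, > 100000 nM.
Compound 3, `Cc1ccc(S/C(=C/c2cc(C)cc(C)c2)C(=O)c2ccc(Cl)cc2)cc1` — 50000 nM.

Compound 1 sits at a limit of this assay, not at a number. Compound 2 likewise sits at a limit of this assay. The two cores of compound 1 and compound 2 differ by (4-methylphenyl)sulfonyl in place of (4-methylphenyl)sulfanyl on a double-bonded chain carbon bound to a carbonyl carbon and a double-bonded chain carbon, and the step that the two limits leave unreadable from compound 1 to compound 2 cannot be read because the limit of > 100000 nM in this assay, at which 2 of the 3 values shown sit, holds both ends. From compound 1 to compound 3 the change is 3,5-dimethylphenyl in place of 2,4,6-trihydroxyphenyl on a double-bonded chain carbon bound to a double-bonded chain carbon, and the step of an at least 2.0-fold lower number from compound 1 to compound 3 (0.30 log units; that floor lies within the scatter) is a floor, since compound 1 gives only a limit.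

Compound 4, `Cc1ccc(S(=O)(=O)/C(=C/c2cc(C)cc(C)c2)C(=O)c2ccc(Cl)cc2)cc1`, is not yet measured. Going by the values given here, it differs from compound 2 by 3,5-dimethylphenyl in place of 2,4,6-trihydroxyphenyl on a double-bonded chain carbon bound to a double-bonded chain carbon, which is the same change as the one from compound 1 to compound 3, at the same place. In this assay the step of an at least 1.6-fold lower number from compound 2 to compound 4 (0.22 log units; that floor lies within the scatter) is expected to run in the same direction, resting on compound 3, whose value 50000 nM is a measured number after the same change. Whether the sulfonyl core moves the same way is not tested by any measured pair here, so the expected range is wide and a limit result remains possible. Compound 4 is estimated at 60000 nM, with a range from 20000 nM to 150000 nM.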

Compound 4, concentration for 50% growth inhibition: 1000 nM
For compound 4 the middle estimate is 60-fold (1.78 log units) above the measured one; measured number outside the range, below it.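

In this assay, going by these compounds alone, 3,5-dimethylphenyl in place of 2,4,6-trihydroxyphenyl gives an at least 100-fold lower number from compound 2 to compound 4 (2.00 log units; beyond the scatter), so on the core of compound 2 the change carries a large drop in the number, and compound 4 is the only member of this set with a value well clear of the limit. The same change has now been read on two cores, but this does not establish that it transfers with a fixed size, and the two steps cannot be ranked: the same change on two cores in this assay, an at least 2.0-fold lower number (0.30 log units; that floor lies within the scatter) from compound 1 to compound 3 and an at least 100-fold lower number (2.00 log units; beyond the scatter) from compound 2 to compound 4; the limit leaves it open whether they differ Both starting compounds, compound 1 and compound 2, sit at one shared limit and not at numbers, so each step is only a floor and the true size on either core remains unknown: the limit of > 100000 nM in this assay, at which 2 of the 4 values shown sit.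

With 3,5-dimethylphenyl in place, compound 3 gives 50000 nM and compound 4 gives 1000 nM, which leaves open whether the sulfonyl form holds its value with other groups on the double-bonded chain carbon. Also open, on these data alone, is whether the result follows from losing the hydroxyl groups or from gaining the methyl groups, which a phenyl ring bearing methoxy groups, an amine or a carboxylic acid at that place could help separate.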